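From 2-chlorophenyl to 4-bromophenyl: a single swap

A few compounds are considered here, and "the series" means these few. Any claim that something is new, unique, unknown or untested is made for them only; others in the source may bear on it.

Within the data shown here, only two numbers are available so far. In a functional assay on HL-60 cells (Homo sapiens) for inhibition, read by MTT assay, with a stated time of 72 h, tested at 30 uM (on this read-out higher numbers stand for more inhibition of growth at the one concentration tested and lower numbers for less inhibition of growth), compound 1 `C=CCc1ccc(OCc2cn(-c3ccccc3Cl)nn2)c(O)c1` gives 38.7% and compound 2 `C#CCOc1ccc(CC=C)cc1O` gives 30.7% on the same test. That gap lies within the usual scatter of repeated measurements, so compound 1 stands level with compound 2 and the two cannot be told apart.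

Compound 3 `C=CCc1ccc(OCc2cn(-c3ccc(Br)cc3)nn2)c(O)c1` has not been measured yet. It keeps the core of compound 1 and alters one group, with 4-bromophenyl in place of 2-chlorophenyl on an aromatic nitrogen of a five-membered aromatic ring with 3 nitrogen (4-bromophenyl in place of 2-chlorophenyl on an aromatic nitrogen). Among the measured compounds shown here, no measured pair of compounds shows what a swap of this kind does, so the only anchor is compound 1 at 38.7% on this scale. The estimated step of a number 2.3 percentage points higher from compound 1 to compound 3 (within the scatter) lies within the scatter, so no clear change in either direction is expected. With so little to go on, the expected range has to be wide. In this assay the estimate for compound 3 is 41%, with an expected range from 25% to 58%.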

Compound 3, percent growth inhibition at one concentration: 22.1%
Compound 3: the middle estimate sits 18.9 percentage points above what was measured, outside the stated range (below it).
By their numbers in this assay, from the lowest: compounds 3, 2 and 1 (each within the scatter of the next, the first and the last beyond it).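

In this assay the group on the aromatic nitrogen turns out to matter: a number 16.6 percentage points lower from compound 1 to compound 3 (beyond the scatter) is a modest step, but it lies beyond the scatter, so this position does not accept every halogen-bearing phenyl group equally. The count of features does not separate the two groups, since 2-chlorophenyl and 4-bromophenyl have the same number of heavy atoms, one six-membered aromatic ring of carbon only, no hydrogen-bond donors or acceptors and no net charge; what differs is which halogen is present and where it sits on the phenyl ring, and both change in this single swap. No measurement here bears on why growth inhibition falls with this change.

The step therefore cannot be assigned to the halogen or to its place on the ring, and 2-bromophenyl and 4-chlorophenyl are the two groups that would pull these apart on the same core. The compounds shown also leave open how a plain phenyl, or a phenyl carrying an amine or a carboxylic acid, would behave at this position.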